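A few compounds are considered here, and "the series" means these few. Any claim that something is new, unique, unknown or untested is made for them only; others in the source may bear on it.

Measured compounds in an ADME assay on HEK293 cells (Homo sapiens) for cytotoxicity, read by MTT assay, with a stated time of 48 h; on this read-out lower numbers stand for stronger inhibition and higher numbers for weaker inhibition:

Compound 1, `CCS(=O)(=O)Nc1ccc(NC(=O)c2cccc(C(F)(F)F)c2)cc1OC`: compound 1 gives > 250000 nM, a limit of the assay.
Compound 2, `CCS(=O)(=O)Nc1ccc(NC(=O)c2cc(C(F)(F)F)cc(C(F)(F)F)c2)cc1OC`: compound 2 gives > 250000 nM, a limit of the assay.
Compound 3, `O=C(Nc1ccc(NS(=O)(=O)C(F)(F)F)c(F)c1)c1cccc(C(F)(F)F)c1`: compound 3 gives 152000 nM.

Among the measured compounds shown here, compound 3 carries the only number among the three; the other two values are limits. The two limits are the same one, (the limit of > 250000 nM in this assay, at which 2 of the 3 values shown sit), so the step from compound 1 to compound 2 cannot be read: a step that the two limits leave unreadable from compound 1 to compound 2. The structural change behind that step is trifluoromethyl in place of hydrogen on an aromatic carbon.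

The difference between the core of compound 1 and the core of compound 3 is not broken down here.

Compound 4, `O=C(Nc1ccc(NS(=O)(=O)C(F)(F)F)c(F)c1)c1cc(C(F)(F)F)cc(C(F)(F)F)c1`, has not yet been measured in this assay. For the measured compounds named here, it differs from compound 3 by trifluoromethyl in place of hydrogen on an aromatic carbon, which is the same change as the one from compound 1 to compound 2, placed in the same way. Going by the values given here, since the only earlier instance of this change sits between two limits, it gives no readable size to lean on; the number for compound 3 is the only anchor. Compound 4 is therefore expected to remain within the usual scatter of compound 3, and the expected step is a 1.3-fold lower number from compound 3 to compound 4 (0.10 log units; within the scatter). In this assay compound 4 is estimated to give 120000 nM, with a range from 50000 nM to 250000 nM, and with a real chance that only a limit is reported.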

Compound 4, half-maximal inhibitory concentration: 164000 nM
Estimate against measurement, compound 4: 1.4-fold (0.14 log units) below; the range from low to high includes it.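

In this assay, trifluoromethyl in place of hydrogen on an aromatic carbon of the core of compound 3 gives a 1.1-fold higher number from compound 3 to compound 4 (0.03 log units; within the scatter), so on this core the added group, which sits meta to a trifluoromethyl group, leaves the read-out within the usual scatter. The same change on the core of compound 1 cannot be read, because compound 1 and compound 2 both give a limit of the assay and not a number: the limit of > 250000 nM in this assay, at which 2 of the 4 values shown sit. The change therefore has a readable size on one core only, which shows that it need not shift this cytotoxicity read-out, but it does not show that the size carries over to the core of compound 1, where any step stays hidden behind the limit.

The compounds shown leave open whether a different group in that same place, such as an amine, a carboxylic acid or a nitrile, would give a step beyond the scatter, since trifluoromethyl is the only substituent varied there. They also leave open how the differences between the core of compound 1 and the core of compound 3 each contribute, and whether a longer chain in place of the ethyl group of compound 1 would bring its value off the limit.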